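The source may report more compounds than this note shows. Statements on the series, on what has been measured and on what is new or still open speak of the compounds shown alone.

Compound 2 `COc1ccc(C(=O)/C=C/c2cc(-c3cc(OC)c(OC)c(OC)c3)n[nH]2)cc1OC` gives -89% in a functional assay on DU-145 cells (Homo sapiens) for cytotoxicity, read by sulforhodamine B assay, with a stated time of 48 h, tested at 10 uM (on this read-out lower numbers stand for a stronger effect and higher numbers for a weaker effect at the one concentration tested), the lowest of the two numbers measured here. Going by the values given here, compound 1 `COc1cc(-c2cc(/C=C/C(=O)c3ccc(N)cc3)[nH]n2)cc(OC)c1OC` gives -50%, and the single measured step, a number 39 percentage points lower from compound 1 to compound 2 (beyond the scatter), reworks the aryl ring on the carbonyl carbon. Compound 3 `COc1ccc(C(=O)/C=C/c2cc(-c3cc(OC)c(OC)c(OC)c3)n[nH]2)cc1` is still unmeasured and differs from compound 2 only at that same ring: hydrogen in place of methoxy on an aromatic carbon. Among the compounds with values here, the one known step bears on it only loosely, as it swaps the whole ring rather than trimming a single group, so it shows that this ring matters without saying how much one methoxy counts. Compound 3 is therefore expected to change by a number 14 percentage points higher from compound 2 to compound 3 (beyond the scatter), a modest move toward a weaker effect that may still lie within the scatter. The estimate for compound 3 is -75%, with a range from -95% to -45%.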

Compound 3, a percentage reported as activity, at one concentration (the size of the read-out at that concentration, not a potency): -93%
Compound 3: middle estimate off by 18 percentage points, on the high side, within the range that was stated.
By their numbers in this assay, from the lowest: compounds 3 and 2 (each within the scatter of the next); then compound 1.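

In this assay, hydrogen in place of methoxy on the ring gives a number 4 percentage points lower from compound 2 to compound 3 (within the scatter), so at this single concentration 4-methoxyphenyl serves as well as 3,4-dimethoxyphenyl and this second methoxy is not needed to keep the effect. The earlier step swapped a whole ring. The step of a number 43 percentage points lower from compound 1 to compound 3 (beyond the scatter) differs in one group on that ring, with methoxy in place of amino on an aromatic carbon. No measurement shown here offers an explanation for either result.

Still open, on these data alone, is whether the remaining methoxy matters, which a compound carrying hydroxyl, ethoxy or fluorine there, or an unsubstituted phenyl ring, could test. A dimethylamino group at that place could also show whether the large step is specific to the amino group itself.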